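Oxan-4-yl to ethyl on the ring amine of the thienopyridine ureas

The source may hold more compounds than are shown below. What is called first, only, known or untested is meant among the compounds shown, and "the series" means these compounds.

Measured compounds:
- compound 1 `NC(=O)c1c(NC(=O)Nc2ccc(Cl)cc2)sc2c1CCN(C1CCOCC1)C2` — compound 1 gives 2830 nM
- compound 2 `CCN1CCc2c(sc(NC(=O)Nc3ccc4ccccc4c3)c2C(N)=O)C1` — compound 2 gives 1780 nM
- compound 3 `CCC(O)c1cc2c(cc1NC(=O)Nc1ccc(Cl)cc1)OCCO2` — for compound 3 the read-out is a limit, > 25000 nM

All values come from a functional assay (strain AB) with Danio rerio as the target, read by microscopy, with a stated time of 1 h; on this read-out higher numbers stand for an effect only at larger amounts of compound and lower numbers for an effect already at smaller amounts. Compound 1 stands at the highest of the two numbers in this assay, and its nearest neighbour, compound 2, sits within the scatter of it, so no order between the two can be drawn. Compound 3 returns only a limit in this assay (the limit of > 25000 nM in this assay, at which 1 of the 3 values shown sits), and its structure shares with compound 1 the urea to the chlorophenyl ring but not the core.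

Compound 4 `CCN1CCc2c(sc(NC(=O)Nc3ccc(Cl)cc3)c2C(N)=O)C1` is to be measured in this assay. It differs from compound 1 in one place: ethyl in place of oxan-4-yl on an amine nitrogen in a ring. Compound 2 already carries the ethyl on the same ring nitrogen, but it also bears a naphthyl in place of the chlorophenyl, so the two structures differ in two places and the ethyl change cannot be read from them alone.

Among the compounds with values here, no step between measured compounds bears on this change. The expectation for compound 4 is a step of a 1.4-fold lower number from compound 1 to compound 4 (0.15 log units; within the scatter), within the scatter, in the direction of compound 2 at 1780 nM. Compound 4 is estimated at 2000 nM, in the range 700 nM to 6000 nM.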

Compound 4, half-maximal effective concentration: 3120 nM
Beside the measured number, compound 4's estimate is 1.6-fold (0.19 log units) below it, within the range that was stated.
By their numbers in this assay, from the lowest: compounds 2, 1 and 4 (each within the scatter of the next). At a limit, above all of these: compound 3.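

In this assay, ethyl in place of oxan-4-yl on the amine nitrogen in the ring gives a 1.1-fold higher number from compound 1 to compound 4 (0.04 log units; within the scatter). Within the data shown here, compound 1 and compound 4 are the first pair to isolate this position, and the read-out does not separate the two groups, even though the non-aromatic ring and its hydrogen-bond acceptor leave with the oxan-4-yl. Nothing in the data measures a property that would account for this result.

As far as these compounds go, whether the read-out stays this level with a benzyl group, an acetyl group or a longer chain such as hexyl on this nitrogen remains open. Also open, from the compounds shown here alone, is whether a carboxylic acid on such a substituent would move the number beyond the scatter.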